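The compounds below may be only part of what the source reports. "The series", "measured", "known", "first", "only" and "open" are said of these compounds alone.

The measured compounds:

Compound 1, `NCC(N)CC(=O)N1CCN(C(=O)CCn2cccc(O)c2=O)CC1`: in a physicochemical assay, read by spectrophotometry, with a stated time of 10 min, tested at 0.02 mM, in the presence of a further agent that is not named here (a higher number here means a stronger effect of the compound at the concentration tested, a lower number a weaker effect), compound 1 gives 10.3%.
Compound 2, `NCC(N)CCC(=O)N1CCN(C(=O)CCn2cccc(O)c2=O)CC1`: in this assay compound 2 gives 11.8%.
Compound 3, `NCC(N)CCCNC(=O)CCn1cccc(O)c1=O`: in this assay compound 3 gives 12.2%.

All three values sit close together. Compound 1 and compound 2 share one core and differ by a single change, (2,3-diaminopropyl in place of 1,2-diaminoethyl on a saturated chain carbon bound to a carbonyl carbon), and that change made a step of a number 1.5 percentage points higher from compound 1 to compound 2 (within the scatter). Compound 3 is built on a different core, and how its core differs from that of compound 1 is not broken down here.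

Compound 4, `NCC(N)CCCCNC(=O)CCn1cccc(O)c1=O`, is not yet measured. It stands to compound 3 as compound 2 stands to compound 1: the change is 2,3-diaminopropyl in place of 1,2-diaminoethyl on a saturated chain carbon, three bonds along the chain from an amide-type nitrogen. The surroundings are not identical, since in the first pair the group sits on a saturated chain carbon bound to a carbonyl carbon, whereas in the second pair it sits on a saturated chain carbon, three bonds along the chain from an amide-type nitrogen; it is therefore the same kind of change, not the same change. The expectation for the step from compound 3 to compound 4 is a number 1.3 percentage points higher from compound 3 to compound 4 (within the scatter), which rests on compound 1 and compound 2 and their step of a number 1.5 percentage points higher from compound 1 to compound 2 (within the scatter), a step within the scatter. On that basis compound 4 is estimated to give 13.5% in this assay, within a range from 6% to 21%.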

Compound 4, a percentage reported as activity, at one concentration (the size of the read-out at that concentration, not a potency): 12.1%
Beside the measured number, compound 4's estimate is 1.4 percentage points above it; the range from low to high includes it.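

In this assay, putting 2,3-diaminopropyl in place of 1,2-diaminoethyl on the core of compound 3 gives a step of a number 0.1 percentage points lower from compound 3 to compound 4 (within the scatter), and the same kind of change on the core of compound 1 gave a step of a number 1.5 percentage points higher from compound 1 to compound 2 (within the scatter). Carried from one core to the other, the change therefore leaves a step within the scatter in both pairs, but this does not show that it has a shared effect, only that neither pair reveals one that can be told apart from repeated measurement. Nothing given here bears on why the values of these compounds lie so close together.

The compounds shown leave open whether a longer chain such as 3,4-diaminobutyl, a single amine in place of the diamino chain, or a carboxylic acid at that end would give a step beyond the scatter. They also leave open how the change would behave on any core other than these two.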